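This account rests on a few compounds, and the source may have more. Where it says the series, first, only, none or still open, it means among the compounds named here.

Measured in an ADME assay on HEK293 cells (Homo sapiens) for cytotoxicity, read by MTT assay, with a stated time of 72 h; a higher number here means a weaker inhibitor, a lower number a stronger inhibitor:
- Compound 1 `O=C(CN1CCN(C(=O)c2cccc(Cl)c2)CC1)N1CCN(CCCc2c[nH]c3ccc(F)cc23)CC1`: 66200 nM
- Compound 2 `COc1ccc2[nH]cc(CCCN3CCN(C(=O)CN4CCN(C(=O)c5ccccc5)CC4)CC3)c2c1`: > 200000 nM
- Compound 3 `COc1ccc2[nH]cc(CCCN3CCN(C(=O)CN4CCN(C(=O)c5ccc(F)cc5)CC4)CC3)c2c1`: > 200000 nM

Compound 3 gives > 200000 nM, which is a limit of the assay and not a number. It therefore stands at the limit of > 200000 nM in this assay, at which 2 of the 3 values shown sit. Compound 4 `COc1ccc2[nH]cc(CCCN3CCN(C(=O)CN4CCN(C(=O)c5cccc(Cl)c5)CC4)CC3)c2c1` differs from it by one change, (3-chlorophenyl in place of 4-fluorophenyl on a carbonyl carbon). Among the compounds with values here, the one measured step that bears on this group, a step that the two limits leave unreadable from compound 2 to compound 3, gives no size to work from. Within the data shown here, the only number with the 3-chlorophenyl on a carbonyl carbon comes from compound 1, at 66200 nM, although its core differs, so a modest move towards lower numbers is expected. The expected change is an at least 1.5-fold lower number from compound 3 to compound 4 (0.18 log units; that floor lies within the scatter), and it is only an estimate. For compound 4 the estimated value is 130000 nM, with an expected range of 55000 nM to 280000 nM.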

Compound 4, half-maximal inhibitory concentration: 143000 nM
For compound 4 the middle estimate is 1.1-fold (0.04 log units) below the measured one; the measured number falls inside the stated range.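

Of the methoxy compounds, only compound 4 gives a number rather than a limit, so a change at this position can bring the reading into measurable range in this assay. The size stays uncertain: there is an at least 1.3-fold lower number from compound 3 to compound 4 (0.14 log units; that floor lies within the scatter), and an at least 1.3-fold lower number from compound 2 to compound 4 (0.14 log units; that floor lies within the scatter). With the 3-chlorophenyl held fixed, the other end of the molecule also matters, with a 2.2-fold higher number from compound 1 to compound 4 (0.33 log units; beyond the scatter).

The compounds shown leave open whether a bromo or a methyl group in place of the chloro would give a similar number. The same holds for an amine or a carboxylic acid there.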